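A few compounds are considered here, and "the series" means these few. Any claim that something is new, unique, unknown or untested is made for them only; others in the source may bear on it.

In a functional assay on HL-60 cells (Homo sapiens) for cytotoxicity, read by luminescence and CellTiter-Glo, with a stated time of 3 days (on this read-out lower numbers stand for stronger inhibition and higher numbers for weaker inhibition), compound 1 (`O=C(Nc1ccc(C(F)(F)F)cc1)c1cc(Br)c(F)cc1O`) gives 450 nM and compound 2 (`O=C(Nc1ccc(C(F)(F)F)cc1)c1ccc(Cl)cc1O`) gives 630 nM on the same read-out. These two numbers lie within the scatter of each other, so compound 1 stands level with compound 2 and neither can be ranked over the other. Compound 3 (`O=C(Nc1ccc(C(F)(F)F)cc1)c1cc(Br)c(-c2ccccc2)cc1O`) keeps the core of compound 1 and differs in one place: phenyl in place of fluoro on an aromatic carbon (phenyl in place of fluoro on an aromatic carbon, ortho to a bromo group). In this assay, going by the values given here, no measured pair shows what this exchange does, and no measured compound carries the phenyl group, so the expectation is loose. A modest move toward a higher number, meaning weaker inhibition, is expected, though not one clearly beyond the scatter. The expected step is a 1.6-fold higher number from compound 1 to compound 3 (0.19 log units; within the scatter) and the range around it is kept wide on both sides. For compound 3 the estimated value is 700 nM with an expected range from 200 nM to 3000 nM once it is tested.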

Compound 3, half-maximal inhibitory concentration: 540 nM
Compound 3: middle estimate off by 1.3-fold (0.11 log units), on the high side; low and high end bracket the measured number.
By their numbers in this assay, from the lowest: compounds 1, 3 and 2 (each within the scatter of the next).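

In this assay the exchange of fluoro for phenyl, on the aromatic carbon ortho to a bromo group and para to a large group, comes to a 1.2-fold higher number from compound 1 to compound 3 (0.08 log units; within the scatter) and so leaves the two compounds level. The earlier compounds shown here carried no phenyl group, and this pair adds the first sign that this position accepts one six-membered aromatic ring of carbon only, with six heavy atoms in place of a single fluorine, while the number stays within the scatter of that of compound 1. Nothing at hand explains this outcome, and it stands here as an observation only.

One exchange at one position cannot show how far this tolerance reaches, and an amine, a carboxylic acid or a longer chain on the same carbon could behave quite differently from phenyl. From the compounds shown here alone, it also stays open whether the level result holds with the bromo group replaced by another group, and whether it carries over to anything beyond cytotoxicity in this one cell line.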